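The source may hold more compounds than are shown below. What is called first, only, known or untested is meant among the compounds shown, and "the series" means these compounds.

Measured so far in a functional assay on A-375 cells (Homo sapiens) for inhibition, read by sulforhodamine B assay, with a stated time of 6 days; on this read-out lower numbers stand for stronger inhibition and higher numbers for weaker inhibition:
- compound 1 `CNCCNCc1cccc(-c2nc(NC3CCOCC3)c(C)c(-c3ccnc4[nH]ccc34)n2)c1`: 18200 nM
- compound 2 `CNCCNCc1cccc(-c2nc(NC3CCOCC3)c(C)c(-c3cn(C)nc3C)n2)c1`: > 50000 nM
- compound 3 `CNCCNCc1cccc(-c2nc(NC3CCOCC3)c(C)c(-c3ccncc3)n2)c1`: 44300 nM

The entry for compound 2, > 50000 nM, is a limit of the assay and not a number. Of the two real numbers, compound 3 has the higher one, so it sits at the weak end of the series, with a 2.4-fold higher number from compound 1 to compound 3 (0.39 log units; beyond the scatter).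

Compound 4 `CNCCNCc1cccc(-c2nc(NC3CCOCC3)c(C)c(-c3ccc(O)cc3)n2)c1` changes one group of compound 3, on an aromatic carbon next to the ring nitrogen: 4-hydroxyphenyl in place of pyridin-4-yl, (4-hydroxyphenyl in place of pyridin-4-yl on an aromatic carbon).

The measured steps all concern this same place. Besides the step above, there is an at least 2.7-fold higher number from compound 1 to compound 2 (0.43 log units; beyond the scatter), both modest in size, and an at least 1.1-fold lower number from compound 2 to compound 3 (0.05 log units; that floor lies within the scatter). Within the data shown here, no measured compound yet carries a ring of carbon only here. Compound 4 keeps a single six-membered ring at this place, like compound 3 at 44300 nM, so it should stay weak in this assay.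

The expected step, a 1.5-fold lower number from compound 3 to compound 4 (0.17 log units; within the scatter), is not expected to go beyond the scatter. For compound 4 the estimated value is 30000 nM, with an expected range of 12000 nM to 50000 nM.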

Compound 4, half-maximal inhibitory concentration: 24100 nM
Compound 4: the middle estimate sits 1.2-fold (0.10 log units) above what was measured, within the range that was stated.
By their numbers in this assay, from the lowest: compounds 1, 4 and 3 (each within the scatter of the next, the first and the last beyond it). At a limit, above all of these: compound 2.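

With a ring of carbon only at this place, a 1.8-fold lower number from compound 3 to compound 4 (0.26 log units; within the scatter) in this assay, so the ring nitrogen of pyridin-4-yl is not needed to hold this level of inhibition. The 4-hydroxyphenyl group, a single ring, also cannot be told apart from the larger two-ring group of compound 1: a 1.3-fold higher number from compound 1 to compound 4 (0.12 log units; within the scatter), whereas the step between compound 1 and compound 3 lies beyond the scatter. Compound 2 is entered as a limit and not a number, so an at least 2.0-fold lower number from compound 2 to compound 4 (0.31 log units; beyond the scatter) gives only a floor: the limit of > 50000 nM in this assay, at which 1 of the 4 values shown sits.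

Plain phenyl would show whether the hydroxy group of compound 4 contributes anything, and that remains open. Also open, on these data alone, is how a ring carrying an amine or a carboxylic acid in place of that hydroxy group would compare.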